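Methoxy Substitution on the Anilino Ring of Compound 3

This account rests on a few compounds, and the source may have more. Where it says the series, first, only, none or still open, it means among the compounds named here.

Of the compounds shown here, three have been measured in an ADME assay on L02 cells (Homo sapiens) for inhibition, read by CCK-8 assay, with a stated time of 48 h; a higher number here means a weaker inhibitor of growth, a lower number a stronger inhibitor of growth. Compound 1 `Cc1ccccc1Nc1nc(NC2CCCCC2)ncc1Cl` gives only a limit in this assay, > 100000 nM. Compound 2 `Cc1ccccc1Nc1nc(NCc2ccccc2)ncc1Cl` likewise gives only a limit in this assay, > 100000 nM. For the measured compounds named here, compound 3 `CN1CCN(c2ccc(Nc3ncc(Cl)c(Nc4ccccc4)n3)nc2)CC1` gives in this assay 7990 nM, the only number among the three measurements. The other two values sit at the limit of > 100000 nM in this assay, at which 2 of the 3 values shown sit.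

Going by the values given here, the single step between measured compounds that differ in one place, a step that the two limits leave unreadable from compound 1 to compound 2, is left unreadable by the two limits, so its size is not known. Among the compounds with values here, no measured step therefore bears on the change now followed, and the series gives no reading of a methoxy in place of hydrogen.

Compound 4 `COc1ccc(Nc2nc(Nc3ccc(N4CCN(C)CC4)cn3)ncc2Cl)cc1` differs from compound 3 by methoxy in place of hydrogen on an aromatic carbon. With nothing measured in the series speaking to this change, no step beyond the usual scatter is expected from compound 3 to compound 4. The estimate for compound 4 in this assay is 8000 nM, with a range from 3000 nM to 25000 nM. The step this expectation means is a 1.0-fold higher number from compound 3 to compound 4 (0.00 log units; within the scatter), expected to lie within the scatter. The measurement of compound 4 remains to be read.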

Compound 4, concentration for 50% growth inhibition: 3150 nM
For compound 4 the middle estimate is 2.5-fold (0.40 log units) above the measured one; the measured number falls inside the stated range.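

In this assay the series now has its first readable step: a 2.5-fold lower number from compound 3 to compound 4 (0.40 log units; beyond the scatter) for methoxy in place of hydrogen on an aromatic carbon, para to a large group. The anilino ring of compound 3 therefore responds at this place, with phenyl to 4-methoxyphenyl moving the number beyond the scatter towards stronger inhibition of growth, though only modestly. Nothing measured in the series speaks to what lies behind this step, which stands as a reading on a single pair.

One group at one place cannot show whether the step belongs to methoxy itself or to substitution there in general, and an amine, a carboxylic acid or a longer alkoxy chain on the same carbon would separate the two. Also open, as far as these compounds go, is whether the same methoxy would give a readable step on compound 1 or compound 2, whose values in this assay are limits and not numbers.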